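Cyclopentyl Gives Way to 1-(Methoxymethyl)ethyl

This account rests on a few compounds, and the source may have more. Where it says the series, first, only, none or still open, it means among the compounds named here.

Of the compounds shown here, three have been read so far in an ADME assay on microsomes from liver (Homo sapiens) for metabolic stability (on this read-out lower numbers stand for slow clearance and higher numbers for fast clearance), and each reading is a limit. Compound 1 `CC(C)Oc1cc(Oc2ccc(S(C)(=O)=O)cc2)cc(-c2cccc(=O)[nH]2)c1` gives < 8 mL/min/kg as a limit. Compound 2 `CC(C)Oc1cc(Oc2cnc(C(=O)N(C)C)nc2)cc(-c2nccc(=O)[nH]2)c1` gives < 8 mL/min/kg as a limit. Compound 3 `CN(C)C(=O)c1ncc(Oc2cc(OC3CCCC3)cc(-c3nccc(=O)[nH]3)c2)cn1` gives < 8 mL/min/kg as a limit, so its place is known only in that form. The whole set comes down to the limit of < 8 mL/min/kg in this assay, at which 3 of the 3 values shown sit, and holds no exact reading.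

Compound 4 `COC[C@H](C)Oc1cc(Oc2cnc(C(=O)N(C)C)nc2)cc(-c2nccc(=O)[nH]2)c1` carries 1-(methoxymethyl)ethyl in place of the cyclopentyl of compound 3, on an oxygen on an aromatic ring, with 1-(methoxymethyl)ethyl in place of cyclopentyl on an oxygen on an aromatic ring as the full count of the difference. Among the measured compounds shown here, one measured step touches this same place, cyclopentyl in place of isopropyl, and it reads as a step that the two limits leave unreadable from compound 2 to compound 3 with no size to carry over. That leaves no measured ground for a large move in this assay in either direction. The expectation rests on compound 3, whose < 8 mL/min/kg is a limit. The expected step is a step that the limit leaves unreadable from compound 3 to compound 4 and nothing beyond the usual scatter is expected from it. For compound 4 the estimated clearance is 7 mL/min/kg, with an expected range from 4 mL/min/kg to 13 mL/min/kg and a good chance that it too is reported only as a limit.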

Compound 4, clearance in the Homo sapiens assay: < 8 mL/min/kg
Compound 4 gave a limit, no number; the forecaster's own chance of this, stated with the estimate: 75%; the middle value is on the limit's open side.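

In the Homo sapiens assay compound 4 gives < 8 mL/min/kg as a limit. No step from compound 2 or compound 3 to compound 4 can be read: the limit of < 8 mL/min/kg in the Homo sapiens assay, at which 4 of the 4 values shown sit.

The compounds shown leave open how their clearances compare, and whether isopropyl, cyclopentyl and 1-(methoxymethyl)ethyl differ at all on this read-out.

In a physicochemical assay for solubility, in phosphate buffer, measured as kinetic solubility, with a stated time of 24 h, at pH 6.5 (a lower number here means a less soluble compound, a higher number a more soluble compound), compound 3 gives 398000 nM and compound 4 gives 342000 nM as measured numbers. In the physicochemical assay the reading is a 1.2-fold lower number from compound 3 to compound 4 (0.07 log units; within the scatter) and so the two compounds do not separate on this read-out.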